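N-methylation of the five-membered ring nitrogen in compound 1

The source may report more compounds than this note shows. Statements on the series, on what has been measured and on what is new or still open speak of the compounds shown alone.

Working notes on the series. For the measured compounds named here, compound 1 `O=C(Nc1ccc(Oc2ccnc3[nH]ccc23)c(F)c1)c1cc2cccnc2n(-c2ccccc2)c1=O` is the only member with a number: in a functional assay on NCI-H460 cells (Homo sapiens) for antiproliferative activity, read by MTT assay, with a stated time of 72 h (on this read-out higher numbers stand for weaker inhibition and lower numbers for stronger inhibition), compound 1 gives 180 nM. Going by the values given here, compound 2 `O=C(Nc1ccc(Oc2ccnc3[nH]ccc23)c(F)c1)c1cc2cccnc2n(-c2ccc(Cl)cc2)c1=O` belongs to the same series but in this assay compound 2 gives "not determined" (no result reported), and compound 3 `O=C(Nc1ccc(Oc2ccnc3[nH]ccc23)c(F)c1)c1cc2cccnc2n(-c2ccc(Br)cc2F)c1=O` likewise carries no number, since in this assay compound 3 gives "not determined" (no result reported), so no step between measured compounds can be drawn. Compound 4 `Cn1ccc2c(Oc3ccc(NC(=O)c4cc5cccnc5n(-c5ccccc5)c4=O)cc3F)ccnc21` is the next entry awaiting measurement; it differs from compound 1 by methyl in place of hydrogen on an aromatic nitrogen. Among the compounds with values here, with no measured step to lean on, the expectation for compound 4 is a weakening of moderate size, a 3.9-fold higher number from compound 1 to compound 4 (0.59 log units; beyond the scatter), beyond the usual scatter. Compound 4 is therefore estimated at 700 nM, with a range from 200 nM to 3000 nM.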

Compound 4, half-maximal inhibitory concentration: 550 nM
For compound 4 the middle estimate is 1.3-fold (0.10 log units) above the measured one; low and high end bracket the measured number.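

In this assay, methyl in place of hydrogen on an aromatic nitrogen brings a 3.1-fold higher number from compound 1 to compound 4 (0.49 log units; beyond the scatter) as a modest weakening beyond the scatter. For the compounds shown here, this gives the first measured step and shows that antiproliferative activity survives the loss of that hydrogen, though not at full strength. No measurement available on the series accounts for the step.

Still open, from the compounds shown here alone, is how this position responds to groups other than methyl, such as an ethyl group, a longer chain or a chain ending in an amine.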